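A few compounds are considered here, and "the series" means these few. Any claim that something is new, unique, unknown or untested is made for them only; others in the source may bear on it.

Of the compounds shown here, two sharing one core have been measured so far. Compound 1 `CC(Nc1nnc2nncn2n1)C(=O)O` gives 74300 nM in a functional assay on HL-60 cells (Homo sapiens) for inhibition, read by MTT assay, with a stated time of 72 h; a higher number here means a weaker inhibitor, a lower number a stronger inhibitor. Compound 2 `CCCCCC(=O)N1CCN(c2nnc3nncn3n2)CC1` gives 3610 nM in this assay, the lower of the two numbers, and its gap to compound 1 lies beyond the scatter. Compound 3 `CCC(=O)N1CCN(c2nnc3nncn3n2)CC1` is the next structure, carrying (hydrogen in place of propyl on a saturated chain carbon, two bonds along the chain from a carbonyl carbon). Among the compounds with values here, no measured pair shows a step of this kind, so the expectation rests on compound 2 alone. Compound 3 is expected to give a somewhat higher number, with an estimated step of a 2.2-fold higher number from compound 2 to compound 3 (0.35 log units; beyond the scatter). Compound 3 is estimated at 8000 nM, within 3000 nM to 25000 nM.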

Compound 3, half-maximal inhibitory concentration: 10100 nM
Compound 3: the middle estimate sits 1.3-fold (0.10 log units) below what was measured, and the stated range covers the measured number.
By their numbers in this assay, from the lowest: compound 2; then compound 3; then compound 1.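

The length of the acyl chain matters in this assay: hydrogen in place of propyl, on a saturated chain carbon, two bonds along the chain from a carbonyl carbon, gives a 2.8-fold higher number from compound 2 to compound 3 (0.45 log units; beyond the scatter) as a modest step. Within the data shown here, this is the first step read at this position, and the only change on record here is pentylcarbonyl to propanoyl. Nothing measured explains why the number moves. From the compounds shown here alone, whether a longer chain would lower the number further remains open, as does what an amine or a carboxylic acid would do in place of the propyl.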